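A few compounds are considered here, and "the series" means these few. Any claim that something is new, unique, unknown or untested is made for them only; others in the source may bear on it.

Compound 1 `CC1=C(/C=C/C(=O)/C=C/c2ccccc2)C(C)(C)CCC1` gives 20400 nM; compound 2 `CC1=C(/C=C/C(=O)/C=C/c2ccc(F)cc2)C(C)(C)CCC1` gives 7400 nM.

In a functional assay on IMR-32 cells (Homo sapiens) for cytotoxicity, read by sulforhodamine B assay, with a stated time of 48 h (a higher number here means a weaker inhibitor, a lower number a stronger inhibitor), compound 2 stands as the lower of the two numbers, its nearest neighbour being compound 1. Going by the values given here, the only measured step is a 2.8-fold lower number from compound 1 to compound 2 (0.44 log units; beyond the scatter). Compound 3 `CC1=C(/C=C/C(=O)/C=C/c2ccccc2Cl)C(C)(C)CCC1` carries 2-chlorophenyl in place of 4-fluorophenyl on a double-bonded chain carbon bound to a double-bonded chain carbon. Among the compounds with values here, this exchange involves a different halogen and a different place on the ring, so compound 1 and compound 2 give no direct precedent; a shift of roughly the size already seen, in either direction, is plausible. Compound 3 is therefore expected near 9000 nM (range 3500 nM to 25000 nM), an estimated 1.2-fold higher number from compound 2 to compound 3 (0.09 log units; within the scatter).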

Compound 3, half-maximal inhibitory concentration: 13700 nM
Compound 3: middle estimate off by 1.5-fold (0.18 log units), on the low side; the range from low to high includes it.
By their numbers in this assay, from the lowest: compounds 2, 3 and 1 (each within the scatter of the next, the first and the last beyond it).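

In this assay, adding a chloro group to the aromatic ring gives a 1.5-fold lower number from compound 1 to compound 3 (0.17 log units; within the scatter), while 2-chlorophenyl in place of 4-fluorophenyl gives a 1.9-fold higher number from compound 2 to compound 3 (0.27 log units; within the scatter). Compound 3 thus cannot be separated from either neighbour, so the step beyond the scatter seen with the fluoro group of compound 2 does not recur with this chloro group. Nothing measured here offers a reason for this.

Since halogen and ring place changed together, the compounds shown cannot tell which of the two matters. Going by these compounds, how an amine or a methoxy group on the aromatic ring would behave also remains open.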